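Sulfonamide nitrogen substitution in a PLK2 inhibitor series

This account rests on a few compounds, and the source may have more. Where it says the series, first, only, none or still open, it means among the compounds named here.

Measured in an assay for inhibition of serine/threonine-protein kinase PLK2 (Homo sapiens), read by FRET and Z'-LYTE, with a stated time of 1 h; on this read-out lower numbers stand for stronger inhibition and higher numbers for weaker inhibition:
Compound 1 `CC[C@@H]1C(=O)N(C)c2cnc(Nc3ccc(S(=O)(=O)NC)cc3)nc2N1C1CCCC1` gives 3.4 nM.
Compound 2 `CC[C@@H]1C(=O)N(C)c2cnc(Nc3ccc(S(N)(=O)=O)cc3)nc2N1C1CCCC1` gives 10.2 nM.

For the measured compounds named here, compound 2 stands at the higher of the two numbers so far; its nearest neighbour is compound 1, and the gap a 3.0-fold higher number from compound 1 to compound 2 (0.48 log units; beyond the scatter) lies beyond the scatter. Compound 3 `CC[C@@H]1C(=O)N(C)c2cnc(Nc3ccc(S(=O)(=O)NC4CCCC4)cc3)nc2N1C1CCCC1` is not yet measured. It differs from compound 2 by cyclopentyl in place of hydrogen on a sulfonamide nitrogen.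

Going by the values given here, the only measured step that bears on this change is the one at the same sulfonamide nitrogen, a 3.0-fold higher number from compound 1 to compound 2 (0.48 log units; beyond the scatter), where removing a methyl raised the number by a modest but real amount. Going the other way, from the unsubstituted nitrogen to a cyclopentyl group, is a larger addition than a single methyl, and no measured pair shows what a ring of that size does here. The expectation for compound 3 is therefore a lower number than compound 2, roughly in the region of compound 1, with a wide range to cover the unknown effect of the larger group: the step of a 2.0-fold lower number from compound 2 to compound 3 (0.31 log units; beyond the scatter) is estimated. Compound 3 is expected to give 5 nM, between 1.5 nM and 20 nM.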

Compound 3, half-maximal inhibitory concentration: 23.9 nM
Compound 3: middle estimate off by 4.8-fold (0.68 log units), on the low side; measured number above the stated range.
By their numbers in this assay, from the lowest: compound 1; then compound 2; then compound 3.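

In this assay, adding carbon to this sulfonamide nitrogen does not move the number in one direction: the methyl lowered it relative to hydrogen, whereas the cyclopentyl group gives a 2.3-fold higher number from compound 2 to compound 3 (0.37 log units; beyond the scatter). Replacing the methyl with the ring gives a larger rise, a 7.0-fold higher number from compound 1 to compound 3 (0.85 log units; beyond the scatter), so the three compounds order as methyl lowest, hydrogen in the middle and cyclopentyl highest, with every step beyond the scatter. Substitution on this nitrogen is therefore not favourable in itself, and the outcome depends on which group enters, though nothing available explains why the ring raises the number.

The compounds shown leave open where between methyl and cyclopentyl the number turns upward, since an ethyl, an isopropyl or a cyclopropyl group on the same nitrogen would each fill part of that gap. They also leave open whether the rise belongs to carbon-only groups or would persist with a ring or chain carrying other atoms, such as a hydroxyethyl group, a morpholine or a tertiary amine.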